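A few compounds are considered here, and "the series" means these few. Any claim that something is new, unique, unknown or untested is made for them only; others in the source may bear on it.

Compound 2 `OC[C@H]1O[C@@H](n2cnc3c(NCc4cccc(C(F)(F)F)c4)ncnc32)[C@H](O)[C@@H]1O` carries a 3-(trifluoromethyl)phenyl on a saturated chain carbon bound to a nitrogen on an aromatic ring. In a functional assay on HOS cells (Homo sapiens) for antiproliferative activity, with a stated time of 72 h (on this read-out lower numbers stand for stronger inhibition and higher numbers for weaker inhibition), compound 2 gives only the assay limit > 166000 nM. Compound 1 `OC[C@H]1O[C@@H](n2cnc3c(NCc4cccc(O)c4O)ncnc32)[C@H](O)[C@@H]1O` likewise reaches only the limit > 166000 nM in this assay. Going by the values given here, the step that the two limits leave unreadable from compound 1 to compound 2 is therefore not readable, and the series so far sits entirely at the limit of > 166000 nM in this assay, at which 2 of the 2 values shown sit. Compound 3 `OC[C@H]1O[C@@H](n2cnc3c(NCc4ccc(C(F)(F)F)cc4)ncnc32)[C@H](O)[C@@H]1O` differs from compound 2 by 4-(trifluoromethyl)phenyl in place of 3-(trifluoromethyl)phenyl on a saturated chain carbon bound to a nitrogen on an aromatic ring. Among the compounds with values here, no measured step bears on this change, so no shift beyond the scatter is expected; the step that the limit leaves unreadable from compound 2 to compound 3 is an estimate only. Compound 3 is expected to give 200000 nM in this assay, between 50000 nM and 1000000 nM, most likely again as a limit.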

Compound 3, half-maximal inhibitory concentration: > 166000 nM
Compound 3 was reported as a limit; the forecaster's own chance of this, stated with the estimate: 85%; the middle value does not contradict the limit.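

No step among compound 1, compound 2 and compound 3 can be read in this assay, as each value is only a limit: the limit of > 166000 nM in this assay, at which 3 of the 3 values shown sit.

The compounds shown leave open which group, if any, on a saturated chain carbon bound to a nitrogen on an aromatic ring gives a readable value.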